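The compounds below may be only part of what the source reports. "The series", "measured", "known", "first", "only" and "open" are said of these compounds alone.

The measured compounds, each with its result in a toxicity assay on CCRF-CEM cells (Homo sapiens) for cytotoxicity; a lower number here means that less compound is tolerated, a higher number that more compound is tolerated:

Compound 1, `COC(=O)c1cccc2c1nc(-c1c(F)cccc1F)n2Cc1c(F)cccc1F`, gives 57.7 uM.
Compound 2, `CNc1cccc2c1nc(-c1c(F)cccc1F)n2Cc1c(F)cccc1F`, gives 27.2 uM.
Compound 3, `CN(C)C(=O)c1cccc2c1nc(-c1c(F)cccc1F)n2Cc1c(F)cccc1F`, gives 80.1 uM.

Compound 3 holds the highest of the three numbers in this assay. Its nearest neighbour is compound 1, and the step of a 1.4-fold higher number from compound 1 to compound 3 (0.14 log units; within the scatter) lies within the usual scatter, so the two are not distinguishable; the step of a 2.9-fold higher number from compound 2 to compound 3 (0.47 log units; beyond the scatter) is the larger one and lies beyond it.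

The next compound, compound 4, `[N-]=[N+]=NCc1cccc2c1nc(-c1c(F)cccc1F)n2Cc1c(F)cccc1F`, differs from compound 3 in one place: azidomethyl in place of dimethylcarbamoyl on an aromatic carbon.

Two kinds of measured step bear on this. The step of a 1.4-fold higher number from compound 1 to compound 3 (0.14 log units; within the scatter) shows that exchanging one substituent for another on the carbonyl carbon changed little. The steps of a 2.1-fold lower number from compound 1 to compound 2 (0.33 log units; beyond the scatter) and a 2.9-fold higher number from compound 2 to compound 3 (0.47 log units; beyond the scatter) show that when the carbonyl-bearing group was replaced by methylamino, the number fell modestly. Azidomethyl, like methylamino, carries no carbonyl, so a modest lowering from compound 3 is the expectation here, though a result within the scatter cannot be excluded.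

Compound 4 is therefore estimated at 45 uM in this assay, with a range from 18 uM to 110 uM, meaning an expected step of a 1.8-fold lower number from compound 3 to compound 4 (0.25 log units; within the scatter).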

Compound 4, half-maximal toxic concentration: > 100 uM
Compound 4: no number, only a limit; the forecaster's own chance of this, stated with the estimate: 10%; middle value at least 2.2-fold (0.34 log units) away from the limit.
By their numbers in this assay, from the lowest: compound 2; then compounds 1 and 3 (each within the scatter of the next). At a limit, above all of these: compound 4.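

Compound 4 carries no number in this assay, only a limit: the limit of > 100 uM in this assay, at which 1 of the 4 values shown sits.

The exchange of methylamino for azidomethyl gives an at least 3.6-fold higher number from compound 2 to compound 4 (0.56 log units; beyond the scatter) and so separates those two compounds, while the floors in an at least 1.2-fold higher number from compound 3 to compound 4 (0.09 log units; that floor lies within the scatter) and an at least 1.7-fold higher number from compound 1 to compound 4 (0.23 log units; that floor lies within the scatter) do not by themselves separate compound 4 from the two compounds that carry a carbonyl at this aromatic carbon. Going by these compounds alone, what the earlier compounds could not show is that a group without a carbonyl can stand here with no lowering of the number, so the lower number of compound 2 does not follow from the absence of a carbonyl alone.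

The compounds shown leave open how far compound 4 lies past its limit, and with that whether it truly differs from compound 1 and compound 3. They also leave open whether the lower number belongs to methylamino specifically, or whether an aminomethyl group or a carboxylic acid on this aromatic carbon would fall with compound 2 or with compound 4.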